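The compounds below may be only part of what the source reports. "The series", "measured", "known", "first", "only" and "open" are said of these compounds alone.

Compound 2 `CN(C)c1ccc(NC(=O)[C@H](CCCCCC(=O)NO)NC(=O)OCc2ccccc2)cc1` gives 650 nM in a functional assay on NFF cells (Homo sapiens) for antiproliferative activity (on this read-out higher numbers stand for weaker inhibition and lower numbers for stronger inhibition), the highest of the two numbers at hand. Compound 1 `CN(C)c1ccc(NC(=O)[C@H](CCCCCC(=O)NO)NC(=O)/C=C/c2ccccc2)cc1` gives 240 nM in this assay, and the step of a 2.7-fold higher number from compound 1 to compound 2 (0.43 log units; beyond the scatter) changed only the group on a carbonyl carbon. Compound 3 `O=C(CCCCC[C@H](NC(=O)OCc1ccccc1)C(=O)Nc1ccc(-c2ccccc2)cc1)NO` differs from compound 2 in one place: phenyl in place of dimethylamino on an aromatic carbon. Going by the values given here, no measured step changes a group on that aromatic carbon, so the single step from compound 1 to compound 2 does not bear on this change. Among the compounds with values here, with no bearing step, no shift beyond the scatter is expected. Compound 3 is therefore estimated at 700 nM, range 250 nM to 2000 nM. The expected step is a 1.1-fold higher number from compound 2 to compound 3 (0.03 log units; within the scatter).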

Compound 3, half-maximal inhibitory concentration: 2200 nM
Compound 3: the middle estimate sits 3.1-fold (0.50 log units) below what was measured; measured number above the stated range.
By their numbers in this assay, from the lowest: compound 1; then compound 2; then compound 3.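

In this assay the group on this aromatic carbon is not neutral: with the benzyloxy carbonyl side held constant, phenyl in place of dimethylamino gives a 3.4-fold higher number from compound 2 to compound 3 (0.53 log units; beyond the scatter), so 4-phenylphenyl is the weaker of these two aryl amides. Going by these compounds alone, this is the first reading of that position, and the change is of a different place from the earlier carbonyl-side step. No measurement here gives a reason for the shift.

From the compounds shown here alone, whether a primary amine or a methoxy group on the same carbon would track with dimethylamino or with phenyl remains open. Also open, going by these compounds, is whether the step carries over to the 2-phenylethenyl side of compound 1.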